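The source may hold more compounds than are shown below. What is called first, only, known or untested is meant among the compounds shown, and "the series" means these compounds.

Four sugar-like compounds, all carrying three benzyl ether groups on a shared core, were compared for their ability to slow the growth of a human leukaemia cell line. In a functional assay on HL-60 cells (Homo sapiens) for antiproliferative activity, read by MTT assay (on this read-out lower numbers stand for stronger inhibition and higher numbers for weaker inhibition), compound 1 `CCC[C@H]1O[C@H](COCc2ccccc2)[C@@H](OCc2ccccc2)[C@H](OCc2ccccc2)[C@H]1O` gives 28200 nM. Compound 2 `O[C@@H]1[C@@H](OCc2ccccc2)[C@H](OCc2ccccc2)[C@@H](COCc2ccccc2)O[C@@H]1c1ccccc1` is reported as "not active" (no number reported) in this assay, with no number. Compound 3 `CC(C)C[C@@H]1O[C@H](COCc2ccccc2)[C@@H](OCc2ccccc2)[C@H](OCc2ccccc2)[C@@H]1O` is likewise reported as "not active" (no number reported) in this assay, so it stands without a single number, and one further compound in the set shares that fate.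

Compound 4 `CC(C)C[C@H]1O[C@H](COCc2ccccc2)[C@@H](OCc2ccccc2)[C@H](OCc2ccccc2)[C@H]1O` is the partner of compound 3 in this step. The two differ as follows: the two compounds have the same atoms and bonds and differ only in configuration as drawn: 2 of 5 stereo elements differ; a stereocentre at a saturated ring carbon is drawn S in compound 3 and R in compound 4; a stereocentre at a saturated ring carbon is drawn R in compound 3 and S in compound 4. Going by the values given here, since compound 3 has no number, no measured step can be computed here. Given that the only number in the set, from compound 1, is weak, and that compound 3 gives no number at all, the expectation for compound 4 is weak inhibition at best, and a fair chance that this assay again reports no number. Compound 4 is estimated at 25000 nM in this assay, with a likely range from 8000 nM to 80000 nM.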

Compound 4, half-maximal inhibitory concentration: 13900 nM
Compound 4: middle estimate off by 1.8-fold (0.25 log units), on the high side; the range from low to high includes it.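

Methyl in place of hydrogen on a saturated chain carbon bound to two saturated chain carbons gives a 2.0-fold lower number from compound 1 to compound 4 (0.31 log units; beyond the scatter) in this assay. Going by these compounds alone, this is the first measured comparison in the set, and it shows that this place on the chain accepts the extra methyl with a modest gain in inhibition, though the number stays weak. Compound 4 also gives a number where compound 3, reported as not active, gives none, so the configuration as drawn can decide whether any activity is seen with this chain: the fact that compounds 3 and 4 differ only in the configuration as drawn.

As far as these compounds go, whether a longer chain, an amine or a carboxylic acid in this place would strengthen inhibition remains open. Also open is whether configuration matters as much for compound 1 as for compound 4; the compounds shown hold only one such pair.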